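The source may report more compounds than this note shows. Statements on the series, on what has been measured and on what is new or still open speak of the compounds shown alone.

Compound 1 `C=C(C)[C@@H]1CC=C(Cn2cc(COc3ccc(C4NC(=O)NC(C)=C4C(=O)OCC)cc3)nn2)CC1` gives 19200 nM in a functional assay on UACC-62 cells (Homo sapiens) for inhibition, read by sulforhodamine B assay, with a stated time of 48 h; on this read-out lower numbers stand for stronger inhibition of growth and higher numbers for weaker inhibition of growth.
Compound 2 `C=C(C)[C@@H]1CC=C(Cn2cc(COc3ccccc3C3NC(=O)NC(C)=C3C(=O)OCC)nn2)CC1` reaches only a limit in this assay, > 100000 nM, and no number.
Compound 3 `C=C(C)[C@@H]1CC=C(Cn2cc(COc3ccc(C4NC(=O)NC(C)=C4C(C)=O)cc3)nn2)CC1` gives 20500 nM in this assay.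

Compound 1 and compound 2 contain the same atoms joined differently; the difference between the two cores is not broken down here. From compound 1 to compound 3 the change is methyl in place of ethoxy on a carbonyl carbon and it gave a 1.1-fold higher number from compound 1 to compound 3 (0.03 log units; within the scatter). Compound 4 `C=C(C)[C@@H]1CC=C(Cn2cc(COc3ccccc3C3NC(=O)NC(C)=C3C(C)=O)nn2)CC1`, not yet measured in this assay, stands to compound 2 exactly as compound 3 stands to compound 1, the same change at the same place: methyl in place of ethoxy on a carbonyl carbon. Compound 4 is expected at 150000 nM, from 60000 nM to 400000 nM, most likely again as a limit rather than a number, because the measured step of this change was only a 1.1-fold higher number from compound 1 to compound 3 (0.03 log units; within the scatter) and compound 2 sits at the limit of > 100000 nM in this assay, at which 1 of the 3 values shown sits. The step expected for compound 4 is a step that the limit leaves unreadable from compound 2 to compound 4.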

Compound 4, concentration for total growth inhibition: 34200 nM
The estimate for compound 4 lay 4.4-fold (0.64 log units) above the measured number; measured number below the stated range.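

On the core of compound 2, methyl in place of ethoxy on a carbonyl carbon gave an at least 2.9-fold lower number from compound 2 to compound 4 (0.46 log units; beyond the scatter) in this assay. The change therefore did not carry over at a constant size from one core to the other: the same change on two cores in this assay, a 1.1-fold higher number (0.03 log units; within the scatter) from compound 1 to compound 3 and an at least 2.9-fold lower number (0.46 log units; beyond the scatter) from compound 2 to compound 4, at least 3.1-fold (0.49 log units) apart, beyond the scatter of two such steps. Going by these compounds, this rests on a single pair on each core and sets no rule for the series, and the full size of the second step stays unknown, as compound 2 carries only a limit: the limit of > 100000 nM in this assay, at which 1 of the 4 values shown sits.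

The compounds shown leave open how other groups on that carbonyl carbon, such as a carboxylic acid, an amide or a longer chain ester, would fare on the two cores. They also leave open whether any such group would follow the same difference between the cores.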